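From benzyl to 2-hydroxyethyl on the shared core

The source may hold more compounds than are shown below. What is called first, only, known or untested is meant among the compounds shown, and "the series" means these compounds.

Measured in a functional assay on HL-60 cells (Homo sapiens) for cytotoxicity, read by MTT assay, with a stated time of 24 h; on this read-out lower numbers stand for stronger inhibition and higher numbers for weaker inhibition:
- compound 1 `BrCCCCCCOc1c(Br)cc(Br)cc1Oc1ccc(Br)cc1Br` gives 37.8 ug/mL
- compound 2 `CCOC(=O)C(C)Oc1c(Br)cc(Br)cc1Oc1ccc(Br)cc1Br` gives 35.7 ug/mL
- compound 3 `Brc1ccc(Oc2cc(Br)cc(Br)c2OCc2ccccc2)c(Br)c1` gives 27.9 ug/mL

Compound 3 does not stand apart from the other two, as a 1.4-fold lower number from compound 1 to compound 3 (0.13 log units; within the scatter) and a 1.3-fold lower number from compound 2 to compound 3 (0.11 log units; within the scatter) show. The next compound is compound 4 `OCCOc1c(Br)cc(Br)cc1Oc1ccc(Br)cc1Br`, which has hydroxymethyl in place of phenyl on a saturated chain carbon bound to an oxygen on an aromatic ring. Cut one bond further out, this reads benzyl to 2-hydroxyethyl.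

Among the compounds with values here, no measured step makes this exact exchange, and no measured compound carries a hydroxyl group at this place. The nearest evidence is the set of exchanges on the same oxygen, which also includes a 1.1-fold lower number from compound 1 to compound 2 (0.02 log units; within the scatter). All three steps are small, so no step beyond the scatter is expected in this assay, and no direction is favoured. The expected change is a 1.1-fold higher number from compound 3 to compound 4 (0.06 log units; within the scatter). For compound 4 the estimated value is 32 ug/mL, with an expected range of 15 ug/mL to 65 ug/mL.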

Compound 4, half-maximal inhibitory concentration: 28.2 ug/mL
The estimate for compound 4 lay 1.1-fold (0.05 log units) above the measured number; low and high end bracket the measured number.
By their numbers in this assay, from the lowest: compounds 3, 4, 2 and 1 (each within the scatter of the next).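

In this assay, within the data shown here, 2-hydroxyethyl is the only one of the four groups on this oxygen that carries a hydrogen-bond donor, yet exchanging benzyl for it gives a 1.0-fold higher number from compound 3 to compound 4 (0.00 log units; within the scatter) and removes the six-membered aromatic ring without moving the number beyond the scatter. The same compound also stays level with the ester-bearing and bromine-bearing groups, with a 1.3-fold lower number from compound 2 to compound 4 (0.10 log units; within the scatter) and a 1.3-fold lower number from compound 1 to compound 4 (0.13 log units; within the scatter) as the two further steps, so a hydroxyl at this place does not set compound 4 apart from the other compounds. Nothing available explains why these groups read alike.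

Going by these compounds, whether an amine or a carboxylic acid in place of the hydroxyl, or a chain longer than 6-bromohexyl, would give a step beyond the scatter remains open. On these data alone, whether these groups would also read alike on another cell line is equally open.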